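The source may hold more compounds than are shown below. What is called first, only, known or untested is meant among the compounds shown, and "the series" means these compounds.

Measured so far in an assay on HEK293 cells for agonist activity at Toll-like receptor 8 (Homo sapiens), read by spectrophotometry; on this read-out lower numbers stand for an effect already at smaller amounts and higher numbers for an effect only at larger amounts of compound:
- compound 1, `CCCCNc1nc(N)nc(C)c1CC`, gives 1660 nM
- compound 2, `CCCC#Cc1c(C)nc(N)nc1NCCCC`, gives 5000 nM

Compound 2 stands at the higher of the two numbers, that is, it needs more material than compound 1 to reach the same effect. Going by the values given here, the single measured step that joins them, a 3.0-fold higher number from compound 1 to compound 2 (0.48 log units; beyond the scatter), replaces a two-carbon saturated chain on the shared core with a longer chain carrying a triple bond, and it costs potency.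

Compound 3, `C#Cc1c(C)nc(N)nc1NCCCC`, is obtained from compound 2 by a cut in that same chain: hydrogen in place of propyl on a triple-bonded carbon. What remains on the core is the two-carbon ethynyl group, so the chain returns to the length it has in compound 1 while the triple bond stays. The step from compound 1 to compound 2 bears on this directly, but it mixes two changes at once, so only part of its loss can be expected to reverse. In this assay the step from compound 2 to compound 3 is therefore expected to be a modest gain, a 2.0-fold lower number from compound 2 to compound 3 (0.30 log units; within the scatter), with the chance that it stays within the scatter. For compound 3 the expected value is 2500 nM, between 900 nM and 7000 nM.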

Compound 3, half-maximal effective concentration: 4900 nM
Estimate against measurement, compound 3: 2.0-fold (0.29 log units) below, and the stated range covers the measured number.
By their numbers in this assay, from the lowest: compound 1; then compounds 3 and 2 (each within the scatter of the next).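

In this assay, the propyl on the triple-bonded carbon makes no readable difference: the data show a 1.0-fold lower number from compound 2 to compound 3 (0.01 log units; within the scatter) and so pent-1-yn-1-yl and ethynyl cannot be told apart at this position. Set against the ethyl of compound 1, the ethynyl group gives a 3.0-fold higher number from compound 1 to compound 3 (0.47 log units; beyond the scatter) and this is about the same size as the earlier step, a 3.0-fold higher number from compound 1 to compound 2 (0.48 log units; beyond the scatter) which on its own mixed a longer chain with a triple bond. Among these three compounds, then, the higher number goes with the triple bond on the aromatic carbon and not with the length of the chain, although no measurement at hand offers a reason for this.

As far as these compounds go, what remains open is whether a saturated pentyl chain in the same place would stay close to compound 1 or move towards compound 2, which would test chain length without a triple bond. From the compounds shown here alone, it is also open whether a vinyl group, a nitrile or a plain hydrogen on that aromatic carbon would give a lower number than the ethyl group does.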